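Sulfonyl aryl swap on the fluorinated quinoline sulfone series

A few compounds are considered here, and "the series" means these few. Any claim that something is new, unique, unknown or untested is made for them only; others in the source may bear on it.

Compound 1 `O=S(=O)(c1ccc(F)c(Cl)c1)c1cnc2c(F)cccc2c1-c1cccc(Cl)c1` is the reference point. In an ADME assay on microsomes from liver (Homo sapiens) for metabolic stability, tested at 2.5 uM (on this read-out lower numbers stand for slow clearance and higher numbers for fast clearance), compound 1 gives 0.18 mL/min, the second highest of the three numbers in hand. Among the measured compounds shown here, compound 3 `O=S(=O)(c1ccc(F)c(Cl)c1)c1cnc2c(F)cccc2c1-c1ccccc1F` sits nearest, with 1.39 mL/min in this assay; the step of a 7.7-fold higher number from compound 1 to compound 3 (0.89 log units; beyond the scatter) is the only single-point change measured in the set. For the measured compounds named here, compound 2 `O=S(=O)(c1ccc(F)cc1)c1cnc2cc(Cl)c(F)cc2c1-c1ccc(Cl)cc1` is furthest away, with 0.01 mL/min in this assay, though it differs from compound 1 in more than one place and no step is counted for that pair.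

Compound 4 `COc1ccc(S(=O)(=O)c2cnc3c(F)cccc3c2-c2cccc(Cl)c2)cc1` is the next member. It differs from compound 1 by 4-methoxyphenyl in place of 3-chloro-4-fluorophenyl on a sulfonyl sulfur. Going by the values given here, the measured step from compound 1 to compound 3 changes the aryl on the aromatic carbon, not the aryl on the sulfonyl sulfur, so no measured step bears on this change and no direction can be read from the data. In this assay compound 4 is therefore expected to land near compound 1, with the estimate 0.22 mL/min spanning 0.04 mL/min to 1.2 mL/min, which is the expected step of a 1.2-fold higher number from compound 1 to compound 4 (0.09 log units; within the scatter).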

Compound 4, intrinsic clearance in a liver preparation (reported as CLH), per the amount of preparation that the assay uses: 2.75 mL/min
Estimate against measurement, compound 4: 13-fold (1.10 log units) below, and the stated range ends below it.
By their numbers in this assay, from the lowest: compound 2; then compound 1; then compounds 3 and 4 (each within the scatter of the next).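

Among the compounds shown here, the aryl on the sulfonyl sulfur is a sensitive place in this assay: 4-methoxyphenyl in place of 3-chloro-4-fluorophenyl gives a 15-fold higher number from compound 1 to compound 4 (1.18 log units; beyond the scatter), the first measured change at this place. Together with a 7.7-fold higher number from compound 1 to compound 3 (0.89 log units; beyond the scatter), on an aromatic carbon, this makes two single-place changes away from compound 1, and each gives a higher number beyond the scatter, so clearance in this small set responds to both aryl groups. Nothing in hand gives a reason for the new step.

This change removes the chloro and fluoro groups and adds the methoxy group in one move, so the part of the swap that carries the step remains unresolved. Also open, from the compounds shown here alone, is how a carboxylic acid or an amine on the sulfonyl aryl would read in this assay.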